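Replacing the nitrogen group on a compound at the limit

The compounds below may be only part of what the source reports. "The series", "measured", "known", "first", "only" and "open" are said of these compounds alone.

In a functional assay on BXPC-3 cells (Homo sapiens) for inhibition, read by XTT assay, with a stated time of 72 h (on this read-out higher numbers stand for weaker inhibition and lower numbers for stronger inhibition), compound 1 (`CCCCCC/C=C/CCCCCCCCOC[C@H]1NC[C@H](O)[C@@H]1O`) gives > 100000 nM as a limit. Compound 2 (`C=CCCCCCCCCCOC[C@@H]1CCCN1C(=O)OC(C)(C)C`) gives 50000 nM as a measured number. Compound 3 (`CCCCCCCC/C=C\CCCCCCCCOC[C@@H]1CCCN1C(=O)OC(C)(C)C`) gives > 100000 nM as a limit too, so it has no number of its own. The data therefore sit largely at the limit of > 100000 nM in this assay, at which 2 of the 3 values shown sit, in this series. Compound 4 (`CCCCCCCC/C=C\CCCCCCCCOC[C@@H]1CCCN1[S+]([O-])c1ccc(C)cc1`) differs from compound 3 by a group of 9 heavy atoms (7 carbon, 1 oxygen, 1 sulfur; one six-membered aromatic ring of carbon only) in place of a group of 7 heavy atoms (5 carbon, 2 oxygen; no ring), on an amine nitrogen in a ring and keeps the chain unchanged. Within the data shown here, the one measured step, an at least 2.0-fold higher number from compound 2 to compound 3 (0.30 log units; that floor lies within the scatter), lies in the chain and leaves the nitrogen group untouched, so it gives little guidance here. The expected step is an at least 1.2-fold lower number from compound 3 to compound 4 (0.09 log units; that floor lies within the scatter) and no clear move beyond the scatter is expected. Compound 4 is estimated at 80000 nM (30000 nM to 200000 nM).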

Compound 4, half-maximal inhibitory concentration: > 100000 nM
Compound 4: no number, only a limit; the forecaster's own chance of this, stated with the estimate: 60%; at least 1.2-fold (0.09 log units) between middle value and limit.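

Compound 3 and compound 4 both stand only as limits in this assay, and no step can be read between them: the limit of > 100000 nM in this assay, at which 3 of the 4 values shown sit.

Going by these compounds, how the tert-butoxycarbonyl group and the group that replaces it compare on the amine nitrogen stays open.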